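Swapping pyridin-4-yl for 4-methylphenyl in compound 1

The source may hold more compounds than are shown below. What is called first, only, known or untested is meant among the compounds shown, and "the series" means these compounds.

In a physicochemical assay for lipophilicity, read by HPLC (a higher number here means a more lipophilic compound, a lower number a more polar compound), compound 1 (`O=C1/C(=C/c2ccncc2)C(c2ccccc2)Oc2ccccc21`) gives 2.98. This is level, within the scatter, with compound 2 (`O=C1/C(=C\c2ccncc2)C(c2ccccc2)Oc2ccccc21`) at 2.85. Compound 3 (`O=C1/C(=C\c2ccccc2)C(c2ccccc2)Oc2ccc(O)cc21`) gives 3.45. Its reading lies higher than that of compound 1, and the gap is beyond the scatter.

Compound 4 (`Cc1ccc(/C=C2/C(=O)c3ccccc3OC2c2ccccc2)cc1`) has 4-methylphenyl in place of pyridin-4-yl on a double-bonded chain carbon bound to a double-bonded ring carbon. Within the data shown here, the only measured step, a number 0.13 log units lower from compound 1 to compound 2 (within the scatter), alters the double bond alone and leaves this group untouched, so it gives no size for the swap. The nearest guide is compound 3, which has a six-membered aromatic ring of carbon only at that place and reads 3.45. It is a loose guide, since its core also carries a hydroxyl group. A rise beyond the scatter is therefore expected, estimated as a number 1.22 log units higher from compound 1 to compound 4 (beyond the scatter). For compound 4 the expected value is 4.2, with an estimated range from 3.7 to 4.8.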

Compound 4, partition coefficient: 4.36
Compound 4: middle estimate off by 0.16 log units, on the low side, within the range that was stated.
By their numbers in this assay, from the lowest: compounds 2 and 1 (each within the scatter of the next); then compound 3; then compound 4.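

Among these compounds, the only earlier step, a number 0.13 log units lower from compound 1 to compound 2 (within the scatter), left this group untouched, so compound 4 gives the first size for a change on the double-bonded chain carbon bound to a double-bonded ring carbon: in this assay there is a number 1.38 log units higher from compound 1 to compound 4 (beyond the scatter). This single swap makes several changes at once, since the ring loses its nitrogen and its hydrogen-bond acceptor, while the new 4-methylphenyl group also brings a methyl group. The information available offers no explanation for the size of this step.

The pair cannot show how much of the step belongs to the lost ring nitrogen and how much to the added methyl group. From the compounds shown here alone, how an amine, a carboxylic acid or a longer chain on the aromatic ring would read at this place also stays open.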